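Tetrazole substituent variation in a fatty-acid amide hydrolase series

The source may report more compounds than this note shows. Statements on the series, on what has been measured and on what is new or still open speak of the compounds shown alone.

Measured compounds:
compound 1 `CCCCCCCCc1ccc(OCC(=O)Cn2nnc(SC)n2)cc1` — 31 nM
compound 2 `CCCCCCCCc1ccc(OCC(=O)Cn2nnc(Cc3ccccc3)n2)cc1` — 66 nM
compound 3 `CCCCCCCCc1ccc(OCC(=O)Cn2nnc(C(=O)OC)n2)cc1` — 88 nM

All three share one core and differ only in the group on the tetrazole carbon. In an assay on microsomes from brain for inhibition of Fatty-acid amide hydrolase 1 (Rattus norvegicus), read by fluorescence and HPLC, with a stated time of 60 min (a higher number here means a weaker inhibitor, a lower number a stronger inhibitor), compound 1 gives 31 nM and is the lowest number of the three. The step of a 2.1-fold higher number from compound 1 to compound 2 (0.33 log units; beyond the scatter) and the step of a 2.8-fold higher number from compound 1 to compound 3 (0.45 log units; beyond the scatter) both go upward beyond the scatter, while the step of a 1.3-fold higher number from compound 2 to compound 3 (0.12 log units; within the scatter) stays within it, so compound 3, with 88 nM, holds the highest number but is not separable from compound 2.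

Compound 4 `CCCCCCCCc1ccc(OCC(=O)Cn2nnc(-c3ccc(C(=O)O)cc3)n2)cc1` is not yet measured. It differs from compound 3 by 4-carboxyphenyl in place of methoxycarbonyl on an aromatic carbon. For the measured compounds named here, no measured step exchanges one carbon-bound substituent for a carboxyphenyl group, and none introduces a hydrogen-bond donor at this place; the nearest analogy is the step of a 1.3-fold higher number from compound 2 to compound 3 (0.12 log units; within the scatter), which swapped one larger group for a smaller one with no change beyond the scatter, and the step of a 2.1-fold higher number from compound 1 to compound 2 (0.33 log units; beyond the scatter), where a larger aromatic group gave a modestly higher number. A modest upward step is therefore expected for compound 4 in this assay, of size a 1.7-fold higher number from compound 3 to compound 4 (0.23 log units; within the scatter), though the wide gap in precedent leaves the range broad. The estimate for compound 4 is 150 nM, between 40 nM and 600 nM.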

Compound 4, half-maximal inhibitory concentration: 90 nM
Compound 4: middle estimate off by 1.7-fold (0.22 log units), on the high side; the measured number falls inside the stated range.
By their numbers in this assay, from the lowest: compound 1; then compounds 2, 3 and 4 (each within the scatter of the next).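

At this aromatic carbon, the larger 4-carboxyphenyl, with its six-membered aromatic ring and a hydrogen-bond donor that none of the earlier groups has, could not be told apart in this assay from either methoxycarbonyl (a 1.0-fold higher number from compound 3 to compound 4 (0.01 log units; within the scatter)) or benzyl (a 1.4-fold higher number from compound 2 to compound 4 (0.13 log units; within the scatter)), so neither the added ring nor the donor brought a change beyond the scatter against these two groups. Methylsulfanyl remains the only group set apart from the others, since the new compound also stands modestly above it (a 2.9-fold higher number from compound 1 to compound 4 (0.46 log units; beyond the scatter)), which extends to a third, quite different substituent what compound 2 and compound 3 had already shown. Nothing measured here explains why these three groups cannot be separated or why methylsulfanyl gives the lowest number.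

The compounds shown do not separate the ring from the acid, and a plain phenyl or a 4-methoxycarbonylphenyl group at this carbon would be needed to tell whether the carboxylic acid itself contributes anything. They also leave open whether the lower number belongs to methylsulfanyl alone or would persist with a related sulfur group such as ethylsulfanyl.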